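The source may hold more compounds than are shown below. What is called first, only, known or untested is meant among the compounds shown, and "the series" means these compounds.

Compound 1 `O=C(Nc1ccccc1)Nc1cccc(Nc2nccc(Nc3ccc4[nH]ccc4c3)n2)c1`: 5 mL.min-1.g-1
Compound 2 `O=C(Nc1ccccc1)Nc1cccc(Nc2nccc(Nc3ccc4cc[nH]c4c3)n2)c1`: 2.6 mL.min-1.g-1

In an ADME assay on microsomes from liver (Homo sapiens) for metabolic stability, read by HPLC, with a stated time of 30 min, tested at 0.5 uM (on this read-out lower numbers stand for slow clearance and higher numbers for fast clearance), compound 2 gives 2.6 mL.min-1.g-1, and it stands level with compound 1, given a 1.9-fold lower number from compound 1 to compound 2 (0.28 log units; within the scatter). Compound 3 `Cn1cc2ccc(Nc3ccnc(Nc4cccc(NC(=O)Nc5ccccc5)c4)n3)cc2n1` carries 2-methyl-2H-indazol-6-yl in place of 1H-indol-6-yl on a nitrogen on an aromatic ring. Going by the values given here, the only measured step at this place is a 1.9-fold lower number from compound 1 to compound 2 (0.28 log units; within the scatter), and it stays small. Among the compounds with values here, no measured compound yet shows the 2-methyl-2H-indazol-6-yl group, so the direction remains open and the expectation rests on that one step. The expected change is a 1.3-fold higher number from compound 2 to compound 3 (0.13 log units; within the scatter), with no shift beyond the scatter anticipated. For compound 3 the estimated value is 3.5 mL.min-1.g-1, with an expected range from 1.3 mL.min-1.g-1 to 9 mL.min-1.g-1.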

Compound 3, intrinsic clearance in microsomes in the Homo sapiens assay: 9.1 mL.min-1.g-1
Estimate against measurement, compound 3: 2.6-fold (0.41 log units) below, outside the stated range (above it).
By their numbers in the Homo sapiens assay, from the lowest: compounds 2, 1 and 3 (each within the scatter of the next, the first and the last beyond it).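

In the Homo sapiens assay, 2-methyl-2H-indazol-6-yl in place of 1H-indol-6-yl gives a step beyond the scatter, a 3.5-fold higher number from compound 2 to compound 3 (0.54 log units; beyond the scatter), whereas the step between the two indolyl compounds stayed within it. Set against 1H-indol-5-yl, the same group stays within the scatter, a 1.8-fold higher number from compound 1 to compound 3 (0.26 log units; within the scatter), so the size of the change depends on which compound serves as reference.

The methyl and the added ring nitrogen enter together, and a 1H-indazol-6-yl group would separate them. In a physicochemical assay for lipophilicity, read by HPLC, in phosphate buffer, measured as octanol-water partition, with a stated time of 6 h, at pH 7.4 (on this read-out lower numbers stand for lower lipophilicity and higher numbers for higher lipophilicity), compound 2 gives >= 4, which is a limit of the assay. In the physicochemical assay compound 3 gives >= 4, which is also a limit of the assay. In the physicochemical assay the step from 1H-indol-6-yl to 2-methyl-2H-indazol-6-yl cannot be read, both compounds sitting at a limit: the limit of >= 4 in the physicochemical assay, at which 2 of the 2 values shown sit.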